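Side-chain exchange on the core of compound 1

The source may report more compounds than this note shows. Statements on the series, on what has been measured and on what is new or still open speak of the compounds shown alone.

Compound 1 `CCCCNC(=O)NS(=O)(=O)c1ccc(OCCCO[N+](=O)[O-])cc1` gives > 100000 nM in a functional assay on thoracic aorta (strain Wistar) for inhibition, with Aorta (Rattus norvegicus) as the target, with a stated time of 120 min, in the presence of a further agent that is not named here; a lower number here means that less compound is needed, a higher number that more compound is needed for the effect. That value is a limit of the assay and not a number, so compound 1 has no measured potency to start from, as the limit of > 100000 nM in this assay, at which 1 of the 2 values shown sits, records.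

Compound 2 `CCCCNC(=O)NS(=O)(=O)c1ccc(Oc2no[n+]([O-])c2S(=O)(=O)c2ccccc2)cc1` gives a true reading, with compound 2 at 220 nM in this assay.

Compound 3 `CCCCNC(=O)NS(=O)(=O)c1ccc(OCc2no[n+]([O-])c2C#N)cc1` has not yet been measured. It is reached from compound 1 by a group of 8 heavy atoms (3 carbon, 3 nitrogen, 2 oxygen; one five-membered aromatic ring with 3 hetero atoms) in place of a group of 6 heavy atoms (2 carbon, 1 nitrogen, 3 oxygen; no ring), on a saturated chain carbon bound to an oxygen on an aromatic ring. A group of 8 heavy atoms, with one five-membered aromatic ring with 3 hetero atoms, replaces 2-(nitrooxy)ethyl on a saturated chain carbon bound to an oxygen on an aromatic ring.

Going by the values given here, no measured step supports this change directly, so the expectation is tentative. Among the compounds with values here, its one anchor is compound 2 at 220 nM, whose structure also holds a five-membered aromatic ring with 3 hetero atoms. A large step towards less compound needed is therefore expected, estimated as an at least 200-fold lower number from compound 1 to compound 3 (2.30 log units; beyond the scatter). The expected value for compound 3 is 500 nM, with an estimated range of 80 nM to 3500 nM.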

Compound 3, half-maximal effective concentration: 900 nM
Compound 3: the middle estimate sits 1.8-fold (0.26 log units) below what was measured, and the stated range covers the measured number.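

At the saturated chain carbon bound to an oxygen on an aromatic ring, exchanging 2-(nitrooxy)ethyl for the nitrile-bearing five-membered aromatic ring with 3 hetero atoms gives, in this assay, an at least 110-fold lower number from compound 1 to compound 3 (2.04 log units; beyond the scatter). The size of that step is a floor and not a measured difference, because its starting point is a limit of the assay: the limit of > 100000 nM in this assay, at which 1 of the 3 values shown sits. What is new is that a five-membered aromatic ring with 3 hetero atoms on this saturated chain carbon gives a true reading, with compound 3 at 900 nM, whereas compound 2 had shown a reading with such a ring only without that chain carbon.

Which part of the entering group carries the step stays open, as the compounds shown offer no partner for compound 3 that differs from it only at the nitrile. A carboxylic acid or an amide in place of the nitrile, or a longer chain in place of the single saturated chain carbon, would begin to separate these contributions in this assay.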